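The source may hold more compounds than are shown below. What is called first, only, known or untested is meant among the compounds shown, and "the series" means these compounds.

Of the compounds shown here, two built on one shared core have been measured. Compound 1 `O=C(CCc1ccccc1)Nc1nc2ccccc2c(=O)s1` and compound 2 `COc1cccc(CCCC(=O)Nc2nc3ccccc3c(=O)s2)c1` were both tested in an assay on CHO cells for displacement of a labelled ligand from adenosine receptor A2b (Homo sapiens), read by scintillation counting, with a stated time of 75 min; on this read-out higher numbers stand for weaker inhibition and lower numbers for stronger inhibition. In this assay compound 1 gives 365 nM, and compound 2 gives 302 nM. Compound 2 holds the lowest of the two numbers, though its gap to compound 1 lies within the scatter, so neither is called the stronger. Compound 3 `O=C(CCCc1cccc(Cl)c1)Nc1nc2ccccc2c(=O)s1` differs from compound 2 in one place: chloro in place of methoxy on an aromatic carbon, meta to a large group. Among the compounds with values here, no step between measured compounds covers such a change. Compound 3 is therefore expected to show a step of a 1.1-fold lower number from compound 2 to compound 3 (0.03 log units; within the scatter), none beyond the scatter. For compound 3 in this assay an inhibition constant of 280 nM is estimated, between 120 nM and 650 nM.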

Compound 3, inhibition constant: >= 1000 nM
Compound 3 was reported as a limit; the forecaster's own chance of this, stated with the estimate: 2%; middle value at least 3.5-fold (0.55 log units) from the limit.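

Compound 3 is reported only as a limit in this assay: the limit of >= 1000 nM in this assay, at which 1 of the 3 values shown sits. Chloro in place of methoxy on this aromatic carbon is therefore not a neutral exchange: it gives an at least 3.3-fold higher number from compound 2 to compound 3 (0.51 log units; beyond the scatter), which shows a sensitivity at this position that the two earlier values did not reveal. Placing 3-chlorobenzyl instead of phenyl on the saturated chain gives an at least 2.7-fold higher number from compound 1 to compound 3 (0.43 log units; beyond the scatter).

On these data alone, how far the true number lies past the limit remains open. So does whether hydroxy, fluoro or methyl on this aromatic carbon would behave like methoxy or like chloro.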